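Swapping a chlorophenyl for thiophene in amide inhibitors

A few compounds are considered here, and "the series" means these few. Any claim that something is new, unique, unknown or untested is made for them only; others in the source may bear on it.

Of the compounds shown here, three that share one core have been tested in an assay on HEK293 cells for inhibition of N-acylethanolamine-hydrolyzing acid amidase (Rattus norvegicus), read by LC-MS, with a stated time of 30 min; on this read-out lower numbers stand for stronger inhibition and higher numbers for weaker inhibition. Compound 1 `Cc1ccccc1-c1ccc(CCC(=O)N2CCCC2)cc1` carries a 2-methylphenyl group; in this assay compound 1 gives only a limit, > 100000 nM. Compound 2 `O=C(CCc1ccc(-c2cccc(Cl)c2)cc1)N1CCCC1` carries a 3-chlorophenyl group and gives 25400 nM in this assay. Compound 3 `O=C(CCc1ccc(-c2ccc(Cl)cc2)cc1)N1CCCC1` carries a 4-chlorophenyl group and gives 48600 nM in this assay; of the two measured numbers it stands at the top, though the difference a 1.9-fold higher number from compound 2 to compound 3 (0.28 log units; within the scatter) lies within the scatter. The steps from compound 1 were an at least 3.9-fold lower number from compound 1 to compound 2 (0.59 log units; beyond the scatter) and an at least 2.0-fold lower number from compound 1 to compound 3 (0.31 log units; beyond the scatter).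

Compound 4 `O=C(CCc1ccc(-c2cccs2)cc1)N1CCCC1` has not been measured. Its change from compound 3 is thiophen-2-yl in place of 4-chlorophenyl on an aromatic carbon. Every measured step keeps a six-membered aromatic ring of carbon only and changes just the group on it; none exchanges that ring for a five-membered one, so none bears directly on this change. The nearest step, a 1.9-fold higher number from compound 2 to compound 3 (0.28 log units; within the scatter), was within the scatter. A number close to that of compound 3 is therefore expected. Compound 4 is estimated at 50000 nM, with a range from 15000 nM to 150000 nM. The expected step is a 1.0-fold higher number from compound 3 to compound 4 (0.01 log units; within the scatter), which is within the scatter.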

Compound 4, half-maximal inhibitory concentration: > 100000 nM
Compound 4 gave a limit, no number; the forecaster's own chance of this, stated with the estimate: 25%; middle value at least 2.0-fold (0.30 log units) from the limit.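

Putting thiophen-2-yl at this position in place of a chlorophenyl group weakens inhibition in this assay, giving an at least 2.0-fold higher number from compound 3 to compound 4 (0.31 log units; beyond the scatter) and an at least 3.9-fold higher number from compound 2 to compound 4 (0.59 log units; beyond the scatter). The earlier steps shown here changed only the group on a six-membered ring, whereas this one shows that a five-membered ring without chlorine does not keep the measurable inhibition of compound 2 and compound 3. The step between compound 1 and compound 4 cannot be read, as both values are limits and not numbers: the limit of > 100000 nM in this assay, at which 2 of the 4 values shown sit.

The compounds shown do not separate the loss of the chlorine from the change of ring, since compound 4 differs in both at once. An unsubstituted phenyl group and a chlorothiophene group would pull these two changes apart.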